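A few compounds are considered here, and "the series" means these few. Any claim that something is new, unique, unknown or untested is made for them only; others in the source may bear on it.

Measured compounds:
compound 1 `Nc1nn2c(O)cc(CNNc3ccc(F)cc3)nc2c1[N+](=O)[O-]` — > 100 ug/mL
compound 2 `Nc1nn2c(O)cc(CNCCO)nc2c1[N+](=O)[O-]` — > 50 ug/mL

In an ADME assay (Homo sapiens) for cytotoxicity (on this read-out lower numbers stand for higher toxicity in this test and higher numbers for lower toxicity in this test), compound 1 gives > 100 ug/mL, which is a limit of the assay (the limit of > 100 ug/mL in this assay, at which 1 of the 2 values shown sits). In this assay compound 2 gives > 50 ug/mL, also a limit (the limit of > 50 ug/mL in this assay, at which 1 of the 2 values shown sits). The step that the two limits leave unreadable from compound 1 to compound 2 cannot be read, as both ends sit at limits. Compound 2 therefore stands at a limit and has no number of its own on this read-out.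

Compound 3 `Nc1nn2c(O)cc(CNNC(N)S)nc2c1[N+](=O)[O-]` differs from compound 2 by (amino(sulfanyl)methyl)amino in place of 2-hydroxyethyl on an amine nitrogen. Within the data shown here, no measured step bears on this change with a readable size, since the only step known, a step that the two limits leave unreadable from compound 1 to compound 2, is hidden by two limits. Both measured values lie at limits, so for compound 3 the expectation is a value near the limit as well, with the step that the limit leaves unreadable from compound 2 to compound 3 expected to remain within the scatter. Compound 3 is estimated at 80 ug/mL, with a range from 30 ug/mL to 200 ug/mL.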

Compound 3, half-maximal cytotoxic concentration: > 50 ug/mL
Compound 3: only a limit was reported; the forecaster's own chance of this, stated with the estimate: 65%; the middle value does not contradict the limit.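

In this assay compound 3 gives > 50 ug/mL, a limit of the assay and not a number. Among these compounds, no step among compound 1, compound 2 and compound 3 can be read. The compounds shown leave open whether changing the group on the amine nitrogen alters cytotoxicity at all.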